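The compounds below may be only part of what the source reports. "The series", "measured", "known", "first", "only" and "open" are said of these compounds alone.

Working notes on the series in an ADME assay on HEK293 cells (Homo sapiens) for cytotoxicity, read by CCK-8 assay, with a stated time of 48 h; on this read-out lower numbers stand for stronger inhibition and higher numbers for weaker inhibition. Among the measured compounds shown here, compound 3 (`COc1ccc(/C=C\c2cc(OC)c(OC)c(OC)c2)cc1OCc1ccc(CO)cc1`) gives 37000 nM, the only true number so far. Compound 1 (`COc1ccc(/C=C\c2cc(OC)c(OC)c(OC)c2)cc1OCc1ccc(CN2C[C@H](O)C[C@@H]2C(=O)O)cc1`) gives > 50000 nM, which is a limit of the assay. Compound 2 (`COc1ccc(/C=C\c2cc(OC)c(OC)c(OC)c2)cc1OCc1ccc(CN2CCCCC2C(=O)O)cc1`) gives > 50000 nM, also a limit. The remaining data therefore sit at the limit of > 50000 nM in this assay, at which 2 of the 3 values shown sit.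

Compound 4 (`COc1ccc(/C=C\c2cc(OC)c(OC)c(OC)c2)cc1OCc1ccc(CN2CC(C(=O)O)C2)cc1`) differs from compound 3 as follows: 3-carboxyazetidin-1-yl in place of hydroxy on a saturated chain carbon bound to an aromatic carbon. In words, this is 3-carboxyazetidin-1-yl in place of hydroxy on a saturated chain carbon bound to an aromatic carbon.

For the measured compounds named here, two measured steps bear on this change, and both run the opposite way, towards hydroxy: an at least 1.3-fold lower number from compound 1 to compound 3 (0.13 log units; that floor lies within the scatter) and an at least 1.3-fold lower number from compound 2 to compound 3 (0.13 log units; that floor lies within the scatter). Read in reverse, they suggest a higher number for compound 4, though neither step is shown to exceed the scatter.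

The expected size is a 1.4-fold higher number from compound 3 to compound 4 (0.13 log units; within the scatter), so no step beyond the scatter is expected. For compound 4 the estimated value is 50000 nM, with an expected range of 30000 nM to 90000 nM.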

Compound 4, half-maximal inhibitory concentration: > 50000 nM
Compound 4 ended at the assay's limit; the forecaster's own chance of this, stated with the estimate: 75%; the middle value lies on the limit itself.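

In this assay, 3-carboxyazetidin-1-yl on a saturated chain carbon bound to an aromatic carbon gives an at least 1.3-fold higher number from compound 3 to compound 4 (0.13 log units; that floor lies within the scatter), so the carboxy group on the smaller azetidine ring reaches the same limit as 2-carboxypiperidin-1-yl and 2-carboxy-4-hydroxypyrrolidin-1-yl. Compound 4 gives > 50000 nM, which is a limit, and the limit now holds most of the series: the limit of > 50000 nM in this assay, at which 3 of the 4 values shown sit. The steps from compound 1 and from compound 2 to compound 4 cannot be read, as both ends are limits, so no order among these three groups can be stated.

Open, on these data alone, is whether a plain piperidin-1-yl amine without the carboxylic acid, or a methyl ester of that acid, would give a true number in this assay at this place. Whether the acid or the ring nitrogen accounts for the step from hydroxy also stays open.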